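A few compounds are considered here, and "the series" means these few. Any claim that something is new, unique, unknown or untested is made for them only; others in the source may bear on it.

Measured compounds in the series:
- Compound 1 `CCN(c1ccc(C#N)c(Cl)c1)c1cc(-n2cnc3ccccc32)ccc1C`: 8160 nM
- Compound 2 `CCN(c1cccc(-n2ccnc2)c1)c1ccc(C#N)c(C(F)(F)F)c1`: > 30000 nM (a limit of the assay)
- Compound 3 `CCN(c1ccc(C#N)c(C(F)(F)F)c1)c1cc(-n2ccnc2)ccc1C`: > 30000 nM (a limit of the assay)

Among the compounds with values here, in a functional assay on PC-3 cells (Homo sapiens) for antiproliferative activity, read by CCK-8 assay, with a stated time of 6 days (a higher number here means a weaker inhibitor, a lower number a stronger inhibitor), compound 1 gives 8160 nM, the only actual number in the set. Compound 2 reaches only the limit > 30000 nM. Compound 3 likewise stops at the limit > 30000 nM. Within the data shown here, the single step between measured compounds differing in one place, a step that the two limits leave unreadable from compound 2 to compound 3, has both ends at the limit of > 30000 nM in this assay, at which 2 of the 3 values shown sit, so its size cannot be read.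

Compound 4 `CCN(c1ccc(C#N)c(Cl)c1)c1cc(-c2ccoc2)ccc1C` is not yet measured in this assay. It differs from compound 1 by furan-3-yl in place of 1H-benzimidazol-1-yl on an aromatic carbon. Among the measured compounds shown here, no measured step involves this substituent position, and the one measured step concerns a methyl group and is unreadable in any case, so the data give no footing for the direction or size of this change. The estimate rests only on compound 1 at 8160 nM as the starting point and on wide uncertainty. Compound 4 is expected at 15000 nM, with a range of 4000 nM to 30000 nM. The step of a 1.8-fold higher number from compound 1 to compound 4 (0.26 log units; within the scatter) is thus expected to be modest and is not confidently beyond the scatter.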

Compound 4, half-maximal inhibitory concentration: > 30000 nM
Compound 4: no number, only a limit; the forecaster's own chance of this, stated with the estimate: 35%; middle value at least 2.0-fold (0.30 log units) away from the limit.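

Within the data shown here, at the aromatic carbon meta to a large group and para to a methyl group, this assay now gives the first readable step, an at least 3.6-fold higher number from compound 1 to compound 4 (0.56 log units; beyond the scatter), with furan-3-yl in place of 1H-benzimidazol-1-yl. The value of compound 4, > 30000 nM, is a limit of the assay and not a number. The group at this position therefore matters in this assay, and compound 1 remains the only compound with an actual number: the limit of > 30000 nM in this assay, at which 3 of the 4 values shown sit.

With only these two groups compared at this position, the data cannot tell whether the loss follows from the change of ring, the change of size or both. On these data alone, how a phenyl ring, an amine or a carboxylic acid would behave at this position remains open, and the step from compound 2 to compound 3 still cannot be read.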